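A few compounds are considered here, and "the series" means these few. Any claim that something is new, unique, unknown or untested is made for them only; others in the source may bear on it.

Measured in a functional assay on cells for antagonist activity at Free fatty acid receptor 1 (Homo sapiens), read by TR-FRET and inositol phosphate accumulation, with a stated time of 2 h; on this read-out lower numbers stand for stronger inhibition and higher numbers for weaker inhibition:
compound 1 `Cc1cc(COc2ccccc2Cl)nc(-c2ccccn2)n1`, 316 nM
compound 2 `Cc1cc(COc2ccccc2F)nc(-c2ccccn2)n1`, 398 nM
compound 3 `Cc1cc(COc2ccc(F)cc2)nc(-c2ccccn2)n1`, 631 nM

Compound 3 gives the highest number of the three, yet its gap to compound 2, a 1.6-fold higher number from compound 2 to compound 3 (0.20 log units; within the scatter), and its gap to compound 1, a 2.0-fold higher number from compound 1 to compound 3 (0.30 log units; within the scatter), both lie within the scatter, so no ranking among the three can be drawn. The swap of chloro for fluoro, a 1.3-fold higher number from compound 1 to compound 2 (0.10 log units; within the scatter), also stays within the scatter.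

Compound 4 `Cc1cc(COc2ccc(F)cc2F)nc(-c2ccccn2)n1` differs from compound 3 by fluoro in place of hydrogen on an aromatic carbon. Within the data shown here, no measured step adds a fluoro to a ring that already carries one; the nearest reference is compound 2, whose single fluoro sits on the ring carbon next to the oxygen-bearing carbon, and its value against compound 3 (a 1.6-fold higher number from compound 2 to compound 3 (0.20 log units; within the scatter)) stayed within the scatter. On that basis the expected step from compound 3 to compound 4 in this assay is a 1.4-fold lower number from compound 3 to compound 4 (0.15 log units; within the scatter), that is, no change beyond the scatter, perhaps a slightly lower number. The estimate for compound 4 is 450 nM, with a range of 200 nM to 1000 nM.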

Compound 4, half-maximal inhibitory concentration: 398 nM
Beside the measured number, compound 4's estimate is 1.1-fold (0.05 log units) above it; the range from low to high includes it.
By their numbers in this assay, from the lowest: compounds 1, 2, 4 and 3 (each within the scatter of the next).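

In this assay, fluoro in place of hydrogen on an aromatic carbon, ortho to a large group and meta to a fluoro group, gives a 1.6-fold lower number from compound 3 to compound 4 (0.20 log units; within the scatter) and so adds no readable change at this position. The other single swap leading to the ring of compound 4, also fluoro in place of hydrogen on an aromatic carbon, gives no change at the digits printed from compound 2 to compound 4 (within the scatter) and likewise stays within the scatter, so fluoro is tolerated at both places on this ring when the other is already filled. No measurement bears on what lies behind these steps.

Whether a methoxy group or an amine at this position would move the number beyond the scatter stays open, since the compounds shown carry only chloro or fluoro on this ring. With every step here within the scatter, the compounds shown do not tell whether any place on this ring governs inhibition.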